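The source may report more compounds than this note shows. Statements on the series, on what has been measured and on what is new or still open speak of the compounds shown alone.

Measured so far in a functional assay with Mus musculus as the target; a lower number here means that less compound is needed, a higher number that more compound is needed for the effect:
- compound 1 `Nc1nc(O)c2c(n1)n(C1OC(CO)[C@@H](O)[C@H]1O)c(=O)n2C/C=C/c1ccccc1`: 4 uM
- compound 2 `CCOC(=O)Cn1c(=O)n(C2OC(CO)[C@@H](O)[C@H]2O)c2nc(N)nc(O)c21`: 630 uM

Of these two numbers, compound 2 has the higher, at 630 uM. Compound 3 `Nc1nc(O)c2c(n1)n(C1OC(CO)[C@@H](O)[C@H]1O)c(=O)n2Cc1ccc([N+](=O)[O-])cc1` has not been measured yet. It carries 4-nitrophenyl in place of ethoxycarbonyl on a saturated chain carbon bound to an aromatic nitrogen. Going by the values given here, the one measured step bearing on this is a 160-fold higher number from compound 1 to compound 2 (2.20 log units; beyond the scatter), which is large and also involves ethoxycarbonyl at that place. Like compound 1, compound 3 has an aromatic ring there, so much of that step may be regained, though a single step is thin evidence. The expected step in this assay is large and downward: a 21-fold lower number from compound 2 to compound 3 (1.32 log units; beyond the scatter). For compound 3 the estimate is 30 uM, with an expected range of 5 uM to 200 uM.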

Compound 3, concentration for half-maximal effect: 50 uM
Estimate against measurement, compound 3: 1.7-fold (0.22 log units) below, and the stated range covers the measured number.
By their numbers in this assay, from the lowest: compound 1; then compound 3; then compound 2.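

In this assay, putting an aromatic ring on the saturated chain carbon bound to an aromatic nitrogen gives back part of the large rise seen with ethoxycarbonyl (a 13-fold lower number from compound 2 to compound 3 (1.10 log units; beyond the scatter)). The recovery is only partial, as 4-nitrophenyl does not match 2-phenylethenyl (a 13-fold higher number from compound 1 to compound 3 (1.10 log units; beyond the scatter)). Having an aromatic ring here is therefore not the whole story, and nothing available explains these differences.

From the compounds shown here alone, it remains open whether the remaining gap comes from the nitro group or from the ethenyl link. Going by these compounds, how a plain benzyl, a 4-aminobenzyl or a carboxylic acid would behave at this place is also open.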